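Amide aryl swap on the chromone acrylamide series: cytotoxicity notes

The source may hold more compounds than are shown below. What is called first, only, known or untested is meant among the compounds shown, and "the series" means these compounds.

Three analogues sharing one core have been run in an ADME assay on HepG2 2.2.15 cells (Homo sapiens) for cytotoxicity, read by MTT assay, with stated times of 48 h and 9 days; a higher number here means that more compound is tolerated, a lower number that less compound is tolerated. Compound 1 `COc1ccc2c(=O)c(/C=C/C(=O)Nc3cccc(Cl)c3)coc2c1` gives 1100000 nM. Compound 2 `COc1ccc2c(=O)c(/C=C/C(=O)Nc3cc(C)ccc3C)coc2c1` gives 1100000 nM in this assay, and compound 3 `COc1ccc2c(=O)c(/C=C/C(=O)Nc3ccccc3OC)coc2c1` gives 1050000 nM in this assay. The three aryl groups on the amide nitrogen leave the read-out essentially untouched: no change at the digits printed from compound 1 to compound 2 (within the scatter), a 1.0-fold lower number from compound 1 to compound 3 (0.02 log units; within the scatter) and a 1.0-fold lower number from compound 2 to compound 3 (0.02 log units; within the scatter) all sit within the scatter, so compound 3 stands together with compound 1 and compound 2 rather than apart from them.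

Compound 4 `COc1ccc(NC(=O)/C=C/c2coc3cc(OC)ccc3c2=O)cc1` is the next member, not yet measured in this assay. It differs from compound 3 only at the amide nitrogen: 4-methoxyphenyl in place of 2-methoxyphenyl on an amide-type nitrogen. The bearing steps are those just named, each within the scatter, and the change again touches only the aryl group on the amide nitrogen. The step of no change at the digits printed from compound 3 to compound 4 (within the scatter) is therefore expected to stay within the scatter. Compound 4 is estimated at 1050000 nM in this assay, with a range from 650000 nM to 1600000 nM.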

Compound 4, half-maximal cytotoxic concentration: 718000 nM
Compound 4: the middle estimate sits 1.5-fold (0.17 log units) above what was measured; the measured number falls inside the stated range.
By their numbers in this assay, from the lowest: compounds 4, 3, 1 and 2 (each within the scatter of the next).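

Going by these compounds alone, exchanging 2-methoxyphenyl for 4-methoxyphenyl on the amide-type nitrogen keeps the atoms the same and joins them differently, so this is the first comparison of two placements of one group on the aryl ring, and in this assay it gives a 1.5-fold lower number from compound 3 to compound 4 (0.17 log units; within the scatter). The other two comparisons with the new analogue, a 1.5-fold lower number from compound 2 to compound 4 (0.19 log units; within the scatter) and a 1.5-fold lower number from compound 1 to compound 4 (0.19 log units; within the scatter), also stay within the scatter, so all four aryl groups at this position remain indistinguishable in this read-out. No available evidence bears on why the read-out holds across these changes.

Going by these compounds, it remains open whether an aryl group carrying a carboxylic acid or an amine would give a step beyond the scatter. All four compounds share the same core, so they also say nothing about replacing its methoxy group with a longer alkoxy chain.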